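The source may hold more compounds than are shown below. What is called first, only, known or untested is meant among the compounds shown, and "the series" means these compounds.

Measured compounds:
Compound 1, `CCCCCCCCCCCCNC(=O)[C@@H](NC(=O)c1ccccc1)[C@@H](C)O` — 41200 nM
Compound 2, `CCCCCCCCCCCCNC(=O)[C@@H](NC(=O)c1ccco1)[C@@H](C)O` — 92400 nM
Compound 3, `CCCCCCCCCCCCCCCCCCNC(=O)[C@@H](NC(=O)c1ccccc1)[C@@H](C)O` — 113000 nM

All three were tested in a functional assay on A-431 cells (Homo sapiens) for cytotoxicity, read by MTT assay, with a stated time of 48 h; a higher number here means a weaker inhibitor, a lower number a stronger inhibitor. The change furan-2-yl in place of phenyl on a carbonyl carbon appears twice among the compounds here; in its measured instance it gave a 2.2-fold higher number from compound 1 to compound 2 (0.35 log units; beyond the scatter). Compound 3 differs from compound 1 by hexyl in place of hydrogen on a saturated chain carbon, ten or more bonds along the chain from an amide-type nitrogen, and this gave a 2.7-fold higher number from compound 1 to compound 3 (0.44 log units; beyond the scatter). Compound 4, `CCCCCCCCCCCCCCCCCCNC(=O)[C@@H](NC(=O)c1ccco1)[C@@H](C)O`, carries the same change as compound 2, namely (furan-2-yl in place of phenyl on a carbonyl carbon), but on the core of compound 3. Since the place is described in the same words in both instances, the step from compound 3 to compound 4 is expected to resemble the one already seen, giving about a 2.2-fold higher number from compound 3 to compound 4 (0.34 log units; beyond the scatter), because a 2.2-fold higher number from compound 1 to compound 2 (0.35 log units; beyond the scatter) was modest and beyond the scatter. Compound 4 is therefore estimated at 250000 nM, with a plausible range from 120000 nM to 550000 nM.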

Compound 4, half-maximal inhibitory concentration: 19900 nM
Compound 4: the middle estimate sits 13-fold (1.10 log units) above what was measured, and the stated range ends above it.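

In this assay, furan-2-yl in place of phenyl gave a 5.7-fold lower number from compound 3 to compound 4 (0.75 log units; beyond the scatter), and hexyl in place of hydrogen on the chain gave a 4.6-fold lower number from compound 2 to compound 4 (0.67 log units; beyond the scatter), so each change ran in the opposite direction to its earlier instance. The furan-2-yl change therefore did not carry from one core to the other, although these four compounds do not show why the two changes depend on each other or how general this is: the same change on two cores in this assay, a 2.2-fold higher number (0.35 log units; beyond the scatter) from compound 1 to compound 2 and a 5.7-fold lower number (0.75 log units; beyond the scatter) from compound 3 to compound 4, 13-fold (1.11 log units) apart, beyond the scatter of two such steps. The chain change behaved in the same way: the same change on two cores in this assay, a 2.7-fold higher number (0.44 log units; beyond the scatter) from compound 1 to compound 3 and a 4.6-fold lower number (0.67 log units; beyond the scatter) from compound 2 to compound 4, 13-fold (1.11 log units) apart, beyond the scatter of two such steps.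

The compounds shown leave open whether a thiophen-2-yl group on the carbonyl carbon would follow the same reversal. They also leave open what a shorter or a longer chain would do with either ring.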